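Amide aryl variation on the shared core: compound 4

A few compounds are considered here, and "the series" means these few. Any claim that something is new, unique, unknown or untested is made for them only; others in the source may bear on it.

Measured so far:
compound 1 `COc1ccc(C(=O)Nc2cccc(-c3oc4cc(-c5ccc(F)cc5)ccc4c(=O)c3O)c2)cc1` — 6250 nM
compound 2 `Cc1ccc(C(=O)Nc2cccc(-c3oc4cc(-c5ccc(F)cc5)ccc4c(=O)c3O)c2)cc1` — 2400 nM
compound 3 `COc1ccccc1C(=O)Nc1cccc(-c2oc3cc(-c4ccc(F)cc4)ccc3c(=O)c2O)c1` — 2100 nM

In a functional assay on MCF7 cells (Homo sapiens) for antiproliferative activity, read by CCK-8 assay, with a stated time of 72 h (a lower number here means a stronger inhibitor, a higher number a weaker inhibitor), compound 3 gives the lowest number of the three, with compound 2 within the scatter of it and compound 1 the furthest away. The change to compound 4 `O=C(Nc1cccc(-c2oc3cc(-c4ccc(F)cc4)ccc3c(=O)c2O)c1)c1ccc(-c2ccccc2)cc1` is 4-phenylphenyl in place of 2-methoxyphenyl on a carbonyl carbon. The measured steps on the amide aryl are all modest: a 2.6-fold lower number from compound 1 to compound 2 (0.42 log units; beyond the scatter), a 3.0-fold lower number from compound 1 to compound 3 (0.47 log units; beyond the scatter), and a 1.1-fold lower number from compound 2 to compound 3 (0.06 log units; within the scatter). Within the data shown here, none of them puts an extra aromatic ring at this position, so no step bears directly on it; the expectation is a step in a 1.2-fold higher number from compound 3 to compound 4 (0.09 log units; within the scatter) that stays within the scatter, with wide uncertainty. Compound 4 is estimated at 2600 nM, range 800 nM to 9000 nM.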

Compound 4, half-maximal inhibitory concentration: 38500 nM
For compound 4 the middle estimate is 15-fold (1.17 log units) below the measured one; the measured number lies above the stated range.
By their numbers in this assay, from the lowest: compounds 3 and 2 (each within the scatter of the next); then compound 1; then compound 4.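

In this assay, 4-phenylphenyl on the carbonyl carbon gives what the single-ring amide aryl groups did not: a large loss, with an 18-fold higher number from compound 3 to compound 4 (1.26 log units; beyond the scatter) and a 16-fold higher number from compound 2 to compound 4 (1.21 log units; beyond the scatter), and a modest one even against the weakest earlier compound, with a 6.2-fold higher number from compound 1 to compound 4 (0.79 log units; beyond the scatter). This position therefore does not accept every aromatic group equally, although the earlier changes among single-ring groups stayed modest or within the scatter. Nothing available here accounts for the loss.

Open, as far as these compounds go, is whether a cyclohexyl group in place of the added phenyl would give the same loss. Also open, from the compounds shown here alone, is how an amine or a carboxylic acid on the amide aryl would read.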